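A fluorine shift on the phenyl group, still unmeasured

The source may report more compounds than this note shows. Statements on the series, on what has been measured and on what is new or still open speak of the compounds shown alone.

Compound 1 `COc1cc2c(=O)cc(-c3ccccc3F)[nH]c2cc1O`: 1300 nM
Compound 2 `COc1cc2c(=O)cc(-c3cccc(F)c3)[nH]c2cc1O`: 900 nM

Among the compounds with values here, in a functional assay on HL-60 cells (Homo sapiens) for cytotoxicity, read by MTT assay, with a stated time of 48 h (on this read-out higher numbers stand for weaker inhibition and lower numbers for stronger inhibition), compound 2 sits within the scatter of compound 1, the only other compound measured. Compound 3 `COc1cc2c(=O)cc(-c3ccc(F)cc3)[nH]c2cc1O` has not yet been measured. It differs from compound 2 by 4-fluorophenyl in place of 3-fluorophenyl on an aromatic carbon, with 4-fluorophenyl in place of 3-fluorophenyl on an aromatic carbon. Within the data shown here, the one measured step that bears on this change is a 1.4-fold lower number from compound 1 to compound 2 (0.16 log units; within the scatter). A similarly small change is therefore expected, with no direction favoured. The expected step is a 1.1-fold higher number from compound 2 to compound 3 (0.05 log units; within the scatter). For compound 3 the estimated value is 1000 nM, with an expected range from 450 nM to 2300 nM.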

Compound 3, half-maximal inhibitory concentration: 38200 nM
Compound 3: middle estimate off by 38-fold (1.58 log units), on the low side; measured number above the stated range.
By their numbers in this assay, from the lowest: compounds 2 and 1 (each within the scatter of the next); then compound 3.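

In this assay the place of the fluorine on the phenyl group turns out to matter sharply: 4-fluorophenyl gives a 42-fold higher number from compound 2 to compound 3 (1.63 log units; beyond the scatter) and a 29-fold higher number from compound 1 to compound 3 (1.47 log units; beyond the scatter), while the 2-fluorophenyl and 3-fluorophenyl compounds stay within the scatter of each other. The same atoms, joined differently, can therefore separate compounds widely at this position, which the earlier pair gave no sign of. Nothing available accounts for this loss. Open, on these data alone, is whether chlorine or an amine in place of the fluorine would follow compound 3 or stay with compound 1 and compound 2.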